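The compounds below may be only part of what the source reports. "The series", "measured", "known", "first", "only" and "open" are said of these compounds alone.

Within the data shown here, compound 1 `Cc1cc(O)c(C(=O)/C=C/c2ccc(Cl)cc2)c(-c2ccccc2)c1C(=O)/C=C/c1ccc(Cl)cc1` is one of two compounds tested in an ADME assay on HEK293 cells (Homo sapiens) for cytotoxicity, read by MTT assay, with a stated time of 24 h (on this read-out lower numbers stand for stronger inhibition and higher numbers for weaker inhibition), and, with 10000 nM, it carries the only number reported there; compound 2 `COc1ccc(/C=C/C(=O)c2c(C)cc(O)c(C(=O)/C=C/c3ccc(OC)c(OC)c3)c2-c2ccccc2)cc1OC` was recorded in this assay as "not active" (no number reported). Compound 3 `Cc1cc(O)c(C(=O)/C=C/c2ccc(Cl)cc2)c(-c2ccc(Br)cc2)c1C(=O)/C=C/c1ccc(Cl)cc1` differs from compound 1 in a single place: bromo in place of hydrogen on an aromatic carbon, which, read one bond further out, is phenyl to 4-bromophenyl. Among the measured compounds shown here, no measured pair shows what this exchange does in this assay, so the step is expected to stay within the usual scatter, in no clear direction. Compound 3 is therefore estimated at 8000 nM, with a range from 3000 nM to 25000 nM. The expected step is a 1.3-fold lower number from compound 1 to compound 3 (0.10 log units; within the scatter).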

Compound 3, half-maximal inhibitory concentration: 25000 nM
Beside the measured number, compound 3's estimate is 3.1-fold (0.49 log units) below it; low and high end bracket the measured number.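

Among these compounds, this is the first measured exchange at this position. In this assay, going from phenyl to 4-bromophenyl gives a 2.5-fold higher number from compound 1 to compound 3 (0.40 log units; beyond the scatter), so the position does respond to a new group, and here the bromo goes with weaker inhibition. Nothing measured here explains the shift. The compounds shown leave open whether this step belongs to bromo alone or would also come with fluoro, methoxy or an amine on the same aromatic carbon. They also leave open whether it would hold on a core carrying other side chains.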